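Fluoro removal on the benzylamide of compound 1

A few compounds are considered here, and "the series" means these few. Any claim that something is new, unique, unknown or untested is made for them only; others in the source may bear on it.

Measured so far in an assay on cells for inhibition of Voltage-dependent T-type calcium channel subunit alpha-1I (Homo sapiens), read by patch clamp, tested at 10 uM; a higher number here means more inhibition at the concentration tested (going by the name of the read-out), a lower number less inhibition:
compound 1 `O=C(CC1c2ccccc2N=C(SCCCCCN2CCCC2)N1c1ccccc1)NCc1ccc(F)cc1` gives 22.1%
compound 2 `O=C(CC1c2ccccc2N=C(SCCCCCN2CCCC2)N1c1ccc(-c2ccc(F)cc2)cc1)NCc1ccc(F)cc1` gives 35.1%

Compound 1 stands lowest of the two measured numbers in this assay. Among the compounds with values here, its nearest neighbour is compound 2, and the single measured step, a number 13 percentage points higher from compound 1 to compound 2 (beyond the scatter), comes from 4-fluorophenyl in place of hydrogen on an aromatic carbon, a change at a different place from the one considered here.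

Compound 3 `O=C(CC1c2ccccc2N=C(SCCCCCN2CCCC2)N1c1ccccc1)NCc1ccccc1` is the next compound to be measured in this assay. Its difference from compound 1 is hydrogen in place of fluoro on an aromatic carbon. Within the data shown here, no measured step concerns the fluoro of the 4-fluorobenzyl group, so the step from compound 1 to compound 2 gives no direct guidance for this change. With only the value of compound 1 as an anchor, nothing in the data points to a move in either direction. The step from compound 1 to compound 3 is therefore expected to stay within the scatter, at about a number 2.1 percentage points lower from compound 1 to compound 3 (within the scatter). Compound 3 is estimated at 20%, with a range from 8% to 34%.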

Compound 3, a percentage reported as inhibition, at one concentration (the size of the read-out at that concentration, not a potency): 78.3%
Estimate against measurement, compound 3: 58.3 percentage points below; the whole stated range lies below it.
By their numbers in this assay, from the lowest: compound 1; then compound 2; then compound 3.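

In this assay, the 4-fluorobenzyl group proves to be a sensitive place on compound 1: hydrogen in place of fluoro, on the aromatic carbon para to a large group, gives a number 56.2 percentage points higher from compound 1 to compound 3 (beyond the scatter). This change of a single heavy atom, with no ring, hydrogen-bond donor or acceptor involved, produces a large step, whereas the other change on compound 1 gives a number 13 percentage points higher from compound 1 to compound 2 (beyond the scatter), a modest one, so the benzylamide end cannot be treated as a passive part of the series. Nothing available explains the size of this step.

Going by these compounds, it remains open whether the gain belongs to the loss of fluoro as such or whether other small groups at the same place, such as chloro, methoxy or an amine, would keep part of it. On these data alone, it is also open whether the 4-fluorophenyl substituent that raises the number on compound 1 would do the same on the unsubstituted benzylamide of compound 3.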